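Swapping an acetamido for a methoxy on a nitrile scaffold

The source may report more compounds than this note shows. Statements on the series, on what has been measured and on what is new or still open speak of the compounds shown alone.

Of the compounds shown here, three sharing one core have been measured in a functional assay on HCT-116 cells (Homo sapiens) for cytotoxicity, read by scintillation counting and thymidine incorporation, with a stated time of 72 h; on this read-out lower numbers stand for stronger inhibition and higher numbers for weaker inhibition. Compound 1 `COc1cc(OC)cc(C(=CC#N)c2ccc(OC)c(NC(C)=O)c2)c1` gives 92 nM, which is the second highest of the three numbers. Compound 2 `CCOc1cc(C(=CC#N)c2ccc(OC)c(OC)c2)ccc1OC` gives 200 nM, and compound 3 `CCOc1cc(C(=CC#N)c2ccc(OC)c(O)c2)ccc1OC` gives 15 nM. Among the compounds with values here, the one step measured between neighbours, a 13-fold lower number from compound 2 to compound 3 (1.12 log units; beyond the scatter), shows that a small change at an oxygen on an aromatic ring can shift this read-out a great deal.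

Compound 4 `COc1cc(OC)cc(C(=CC#N)c2ccc(OC)c(OC)c2)c1` differs from compound 1 in a single place: methoxy in place of acetamido on an aromatic carbon. Within the data shown here, no measured pair covers this exact change, so the step from compound 2 to compound 3 is only an indirect pointer, and it concerns a different group. Compound 4 ends up carrying two methoxy groups on that ring, as compound 2 does on the same ring, and compound 2 sits at the high end of the three numbers. A modest move toward a higher number is therefore expected, a 1.6-fold higher number from compound 1 to compound 4 (0.21 log units; within the scatter), with wide uncertainty. Compound 4 is estimated at 150 nM, within 40 nM to 600 nM.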

Compound 4, half-maximal inhibitory concentration: 18 nM
The estimate for compound 4 lay 8.3-fold (0.92 log units) above the measured number; the measured number lies below the stated range.
By their numbers in this assay, from the lowest: compounds 3 and 4 (each within the scatter of the next); then compound 1; then compound 2.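

In this assay, replacing acetamido with methoxy on this aromatic carbon gives a 5.1-fold lower number from compound 1 to compound 4 (0.71 log units; beyond the scatter) and so moves the number down, the opposite direction from what the higher number of compound 2 had suggested. Within the data shown here, until now, the only measured step on this read-out was a change at an oxygen, from methyl to hydrogen; this step shows that exchanging a whole group at this place on the core of compound 1 also matters, and that the acetamido, the larger group and a hydrogen-bond donor, is not required for a low number here. Nothing measured here explains why the number falls.

One step cannot separate the effects of group size and hydrogen-bond donation. An amine or a longer chain such as propoxy at this place could help to tell how far the trend extends.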